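A few compounds are considered here, and "the series" means these few. Any claim that something is new, unique, unknown or untested is made for them only; others in the source may bear on it.

Measured in an ADME assay on NCM460 cells (Homo sapiens) for cytotoxicity, read by CCK-8 assay, with a stated time of 48 h; on this read-out higher numbers stand for weaker inhibition and lower numbers for stronger inhibition:
- Compound 1 `COc1ccc(/C=C\c2cc(OC)c(OC)c(OC)c2)cc1OCc1ccc(C=O)cc1`: 41000 nM
- Compound 2 `COc1ccc(/C=C\c2cc(OC)c(OC)c(OC)c2)cc1OCc1ccc(CN2CC[C@H](C(=O)O)C2)cc1`: > 50000 nM, a limit of the assay and not a number

Compound 2 has no exact place on this scale, and stands at the limit of > 50000 nM in this assay, at which 1 of the 2 values shown sits. In compound 3 `COc1ccc(/C=C\c2cc(OC)c(OC)c(OC)c2)cc1OCc1ccc(CO)cc1`, hydroxy takes the place of 3-carboxypyrrolidin-1-yl on a saturated chain carbon bound to an aromatic carbon: hydroxy in place of 3-carboxypyrrolidin-1-yl on a saturated chain carbon bound to an aromatic carbon. Among the measured compounds shown here, one measured step bears on this change: an at least 1.2-fold higher number from compound 1 to compound 2 (0.08 log units; that floor lies within the scatter). That step introduced the (3-carboxypyrrolidin-1-yl)methyl group which hydroxymethyl now replaces. In this assay, no step beyond the scatter is therefore expected, though a lower number is the likelier direction because compound 1 without that group gives 41000 nM. The expected change is an at least 1.4-fold lower number from compound 2 to compound 3 (0.15 log units; that floor lies within the scatter). For compound 3 the estimated value is 35000 nM, with an expected range of 12000 nM to 50000 nM.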

Compound 3, half-maximal inhibitory concentration: > 50000 nM
Compound 3: no number, only a limit (the forecaster's own chance of this, stated with the estimate: 35%); at least 1.4-fold (0.15 log units) between middle value and limit.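

In this assay, as far as these compounds go, putting hydroxymethyl in place of formyl on an aromatic carbon gives an at least 1.2-fold higher number from compound 1 to compound 3 (0.08 log units; that floor lies within the scatter), so only a small floor on this step can be read and its true size remains unknown. Compound 3 lacks the 3-carboxypyrrolidin-1-yl group of compound 2, yet it also gives a limit of the assay and not a number, so that group is not needed for a reading at this limit. The step between compound 2 and compound 3 cannot be read, as both readings are limits: the limit of > 50000 nM in this assay, at which 2 of the 3 values shown sit.

The compounds shown leave open how far past the limit each of these two compounds lies, and so whether they differ at all. They also leave open where a plain amine or a carboxylic acid without the ring, in place of formyl on an aromatic carbon, would fall on this scale.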